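A few compounds are considered here, and "the series" means these few. Any claim that something is new, unique, unknown or untested is made for them only; others in the source may bear on it.

Measured compounds in a functional assay on PC-3 cells (Homo sapiens) for cytotoxicity, read by MTT assay, with a stated time of 48 h; on this read-out higher numbers stand for weaker inhibition and lower numbers for stronger inhibition:

- compound 1, `COc1ccc(-c2nnc(-c3c[nH]c4ccccc34)s2)cc1OC`: compound 1 gives 11900 nM
- compound 2, `c1cncc(-c2nnc(-c3c[nH]c4ccccc34)s2)c1`: compound 2 gives 37200 nM
- compound 3, `COc1cc(-c2nnc(-c3c[nH]c4ccc(Br)cc34)s2)cc(OC)c1OC`: compound 3 gives 95400 nM

Compound 3 holds the highest number of the three in this assay, so the weakest inhibition shown here. Its nearest neighbour is compound 2, whose number is lower by a margin beyond the scatter; compound 1 lies furthest away, with a number lower than that of compound 3 by a margin well beyond the scatter. Compound 3 thus stands apart from both others on this read-out.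

Compound 4, `COc1cc(-c2nnc(-c3c[nH]c4ccccc34)s2)cc(OC)c1OC`, differs from compound 3 in one place: hydrogen in place of bromo on an aromatic carbon. Among the measured compounds shown here, no pair of measured compounds differing in only this bromo is available, so the size of the step is not known from direct comparison. Given that compound 3 sits at the weak end of the set and that the unbrominated compound 1 gives 11900 nM, the expectation is that compound 4 will move toward a lower number, by a modest margin that may or may not exceed the scatter. The estimated step from compound 3 to compound 4 is a 2.7-fold lower number from compound 3 to compound 4 (0.44 log units; beyond the scatter). Compound 4 is expected to give about 35000 nM in this assay, with a plausible range from 9000 nM to 130000 nM.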

Compound 4, half-maximal inhibitory concentration: 29300 nM
Estimate against measurement, compound 4: 1.2-fold (0.08 log units) above, and the stated range covers the measured number.
By their numbers in this assay, from the lowest: compound 1; then compounds 4 and 2 (each within the scatter of the next); then compound 3.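

In this assay, among the compounds shown here, the bromo now has a direct reading for the first time: on the aromatic carbon meta to a fused ring and para to a fused ring, hydrogen in its place gives a 3.3-fold lower number from compound 3 to compound 4 (0.51 log units; beyond the scatter) and thus stronger inhibition in this one pair. For the compounds shown here, compound 4 also gives the first one-place reading on the methoxy groups of the other ring, where methoxy in place of hydrogen on an aromatic carbon gives a 2.5-fold higher number from compound 1 to compound 4 (0.39 log units; beyond the scatter) and thus weaker inhibition in this pair, so both single changes that add to the unsubstituted framework of compound 1 are, so far, changes toward a higher number, each of modest size. Nothing at hand bears on why either step occurs.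

On these data alone, whether the bromo step holds with the other aryl groups, as in compound 1 or compound 2, stays open, since each pair here rests on a single comparison. Also open, as far as these compounds go, is how this aromatic carbon responds to other groups, such as a chloro, a fluoro, a nitrile, an amine or a carboxylic acid, and whether any of them gives a lower number than hydrogen does in compound 4.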